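The source may report more compounds than this note shows. Statements on the series, on what has been measured and on what is new or still open speak of the compounds shown alone.

Compounds measured so far:
compound 1 `Cc1ccc(-c2onc3ccc(/C=C/C(=O)O)cc23)cc1` – 6510 nM
compound 2 `O=C(O)/C=C/c1ccc2noc(-c3ccc(OC(F)(F)F)cc3)c2c1` – 320 nM
compound 3 `O=C(O)c1ccc2noc(-c3ccc(Oc4ccccn4)cc3)c2c1` – 1190 nM

In an assay for inhibition of inositol hexakisphosphate kinase 2 (Homo sapiens), read by colorimetric assay, coupled enzyme assay and malachite green, with a stated time of 120 min, in the presence of a further agent that is not named here (a higher number here means a weaker inhibitor, a lower number a stronger inhibitor), compound 3 stands second highest of the three numbers; compound 2 gives a lower number, compound 1 a higher one, and both gaps lie beyond the scatter. Compound 4 `O=C(O)c1ccc2noc(-c3ccc(NC(=O)C4CCCC4)cc3)c2c1` differs from compound 3 by one change: (cyclopentylcarbonyl)amino in place of (pyridin-2-yl)oxy on an aromatic carbon. For the measured compounds named here, the only measured step, a 20-fold lower number from compound 1 to compound 2 (1.31 log units; beyond the scatter), also swaps a group at the same position of the same ring, but neither group there resembles the ones exchanged here, so it gives only a loose guide. For compound 4 a step of a 1.2-fold lower number from compound 3 to compound 4 (0.08 log units; within the scatter) in this assay is therefore expected, with no clear direction. The estimated value of compound 4 is 1000 nM, within a range of 250 nM to 4000 nM.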

Compound 4, half-maximal inhibitory concentration: 190 nM
Estimate against measurement, compound 4: 5.3-fold (0.72 log units) above; measured number below the stated range.
By their numbers in this assay, from the lowest: compounds 4 and 2 (each within the scatter of the next); then compound 3; then compound 1.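

In this assay, (cyclopentylcarbonyl)amino in place of (pyridin-2-yl)oxy gives a 6.3-fold lower number from compound 3 to compound 4 (0.80 log units; beyond the scatter), so a non-aromatic ring carried through a carbonyl and an amino link can replace an aromatic ring carried through an oxygen without loss at this position, para to a large group. The earlier step showed this position mattering only in compounds with a different acid side chain; this one shows the same sensitivity with the shorter carboxylic acid. Nothing available explains the gain.

Whether the hydrogen-bond donor, the cyclopentyl ring or both account for it remains open. An acetylamino or (cyclohexylcarbonyl)amino group at this position would help to separate these.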